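The compounds below may be only part of what the source reports. "The series", "measured", "known", "first", "only" and "open" are said of these compounds alone.

Three compounds have been measured in an assay on isolated protein with metabotropic glutamate receptor 2 (Homo sapiens) as the target; a higher number here means that more compound is needed for the effect, a lower number that less compound is needed:
compound 1 `CCS(=O)(=O)N(Cc1cccnc1)c1ccc(C(=O)c2ccccc2)cc1` gives 4200 nM;
compound 2 `CCS(=O)(=O)N(Cc1cccnc1)c1ccc(Cc2ccccc2)cc1` gives 1600 nM;
compound 3 `CCS(=O)(=O)N(Cc1cccnc1)c1cccc(Cc2ccccc2)c1` gives 310 nM.

Compound 3 stands lowest of the three numbers. Within the data shown here, only one step here changes a single place, a 2.6-fold lower number from compound 1 to compound 2 (0.42 log units; beyond the scatter), and it concerns the link between the two outer rings. Compound 2 and compound 3 differ only in where the benzyl sits on the shared core, and their values show a lower number for compound 3.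

Compound 4 `CCS(=O)(=O)N(Cc1cccnc1)c1cccc(OCc2ccccc2)c1` carries benzyloxy in place of benzyl on an aromatic carbon. Among the measured compounds shown here, no measured compound tests an oxygen link, so the expectation rests loosely on the modest linker step between compound 1 and compound 2, and compound 4 is expected to show a 1.2-fold lower number from compound 3 to compound 4 (0.09 log units; within the scatter). The estimate for compound 4 is 250 nM, from 80 nM to 900 nM.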

Compound 4, half-maximal effective concentration: 440 nM
Estimate against measurement, compound 4: 1.8-fold (0.25 log units) below; the measured number falls inside the stated range.
By their numbers in this assay, from the lowest: compounds 3 and 4 (each within the scatter of the next); then compound 2; then compound 1.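

Swapping benzyl for benzyloxy on this aromatic carbon gives a 1.4-fold higher number from compound 3 to compound 4 (0.15 log units; within the scatter), so the two compounds cannot be told apart here. Among these compounds, this is the first look at an oxygen in the link to the outer ring, and at this position the extra atom, which adds a hydrogen-bond acceptor by count, leaves the number within normal repeat variation. Nothing available explains this result. From the compounds shown here alone, whether an amine nitrogen in that link or a longer chain would also leave the number unchanged stays open. So does how benzyloxy would behave at the place where compound 2 carries its benzyl.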